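The compounds below may be only part of what the source reports. "The series", "measured", "known", "first", "only" and "open" are said of these compounds alone.

Measured compounds:
- compound 1, `O=C(c1ccccc1Cl)N1N=C(c2cc3ccccc3oc2=O)CC1c1ccccc1`: 5440 nM
- compound 2, `O=C(CNC1CC1)N1N=C(c2cc3ccccc3oc2=O)CC1c1ccccc1`: "not active" (no number reported)

In a functional assay on HepG2 cells (Homo sapiens) for cytotoxicity, read by MTT assay, with a stated time of 48 h (a lower number here means a stronger inhibitor, a higher number a weaker inhibitor), compound 1 gives 5440 nM. In this assay compound 2 is reported as "not active" (no number reported), so no single number stands for it. Compound 3, `CC(C)(C)NCC(=O)N1N=C(c2cc3ccccc3oc2=O)CC1c1ccccc1`, carries the change (tert-butyl in place of cyclopropyl on an amine nitrogen). Among the compounds with values here, the two compounds share everything else, and no measured pair shows what this change does in this assay, so no shift beyond the usual scatter is expected in either direction. Compound 3 is therefore expected to remain weak, around 20000 nM, between 5000 nM and 80000 nM, with a real chance that only a limit is reported.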

Compound 3, half-maximal inhibitory concentration: 31400 nM
Beside the measured number, compound 3's estimate is 1.6-fold (0.20 log units) below it, within the range that was stated.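

Replacing 2-chlorophenyl on a carbonyl carbon with ((tert-butyl)amino)methyl gives a 5.8-fold higher number from compound 1 to compound 3 (0.76 log units; beyond the scatter) in this assay and so shows, with numbers on both sides, that the group at this place matters. From the compounds shown here alone, the step from compound 2 to compound 3 cannot be read, so the effect of tert-butyl in place of cyclopropyl on the amine nitrogen stays unknown. Nothing at hand explains the shift from compound 1.

The compounds shown leave open how a plain phenyl or a primary amine would read at this carbonyl carbon. They also leave open whether the chlorine of 2-chlorophenyl contributes to the difference.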